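From pyrrolidin-1-yl to (2-methoxyphenyl)amino at a measurement limit

This account rests on a few compounds, and the source may have more. Where it says the series, first, only, none or still open, it means among the compounds named here.

Compound 2 `COc1ccc(C(=O)/C=C/c2ccc(C(=O)N3CCCC3)cc2)c(O)c1` was tested in an ADME assay on SH-SY5Y cells (Homo sapiens) for cytotoxicity, read by MTT assay, with a stated time of 48 h (on this read-out lower numbers stand for stronger inhibition and higher numbers for weaker inhibition), and has no exact number there. Compound 2 gives > 100000 nM as its result, which is a limit and not a number. Compound 1 `COc1ccc(C(=O)/C=C/c2ccc(OCCCOc3ccccc3)c(OC)c2)c(O)c1` gives > 100000 nM as its result, again a limit. Compound 3 `CCOCCCOc1ccc(/C=C/C(=O)c2ccc(OC)cc2O)cc1OC` gives > 100000 nM as its result, also a limit. Compound 2 therefore stands level with the other two, and no order among the three can be read.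

Compound 4 `COc1ccc(C(=O)/C=C/c2ccc(C(=O)Nc3ccccc3OC)cc2)c(O)c1` differs from compound 2 by (2-methoxyphenyl)amino in place of pyrrolidin-1-yl on a carbonyl carbon, and the counted change is (2-methoxyphenyl)amino in place of pyrrolidin-1-yl on a carbonyl carbon in full. Only one measured step links two of these compounds, a step that the two limits leave unreadable from compound 1 to compound 3 with ethyl in place of phenyl on an oxygen on a saturated carbon. That is a different change, and it offers no size to carry over.

Among the compounds with values here, no step beyond the scatter is expected in this assay because the limit of > 100000 nM in this assay, at which 3 of the 3 values shown sit, and no measured step points elsewhere. The expected step is a step that the limit leaves unreadable from compound 2 to compound 4 on this estimate. For compound 4 the estimated value is 120000 nM with a range from 50000 nM to 300000 nM and a strong chance of only a limit.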

Compound 4, half-maximal inhibitory concentration: > 100000 nM
Compound 4: only a limit was reported (the forecaster's own chance of this, stated with the estimate: 80%); the middle value does not contradict the limit.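

Compound 2 and compound 4 each give only a limit and not a number, so no new step can be read between them, and the change from pyrrolidin-1-yl to (2-methoxyphenyl)amino has no readable size: the limit of > 100000 nM in this assay, at which 4 of the 4 values shown sit.

The compounds shown leave open how far any of the four lies from the others in this assay and whether this change alters the result at all.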